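Second trifluoromethyl on the cinnamoyl ring: cytotoxicity notes

The source may hold more compounds than are shown below. What is called first, only, known or untested is meant among the compounds shown, and "the series" means these compounds.

Measured so far:
compound 1 `COc1cc(NC(C)CCCNC(=O)/C=C/c2cccc(C(F)(F)F)c2)c2ncccc2c1` — 16200 nM
compound 2 `COc1cc(NC(C)CCCNC(=O)/C=C/c2cc(C(F)(F)F)cc(C(F)(F)F)c2)c2ncccc2c1` — 158000 nM
compound 3 `COc1cc(NC(C)CCCNC(=O)NNC(=O)/C=C/c2cccc(C(F)(F)F)c2)c2ncccc2c1` — 10600 nM

All three values come from an ADME assay on L6 cells (Rattus norvegicus) for cytotoxicity, read by resazurin assay, with a stated time of 70 h; a lower number here means a stronger inhibitor, a higher number a weaker inhibitor. Within this assay compound 1 and compound 3 lie within the scatter of each other, while compound 2 stands apart from both. The change from compound 1 to compound 2, (trifluoromethyl in place of hydrogen on an aromatic carbon), gave a 9.8-fold higher number from compound 1 to compound 2 (0.99 log units; beyond the scatter). The difference between the core of compound 1 and the core of compound 3 is not broken down here.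

Compound 4 `COc1cc(NC(C)CCCNC(=O)NNC(=O)/C=C/c2cc(C(F)(F)F)cc(C(F)(F)F)c2)c2ncccc2c1` carries the same change relative to compound 3, (trifluoromethyl in place of hydrogen on an aromatic carbon), at a place described in the same words as for the measured pair. Within the data shown here, on that basis the step from compound 3 to compound 4 is expected to be a 9.4-fold higher number from compound 3 to compound 4 (0.97 log units; beyond the scatter), resting on the measured step of a 9.8-fold higher number from compound 1 to compound 2 (0.99 log units; beyond the scatter) as the only precedent, with no other pair available to test it. For compound 4 in this assay the estimate is 100000 nM, expected to fall between 40000 nM and 250000 nM.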

Compound 4, half-maximal inhibitory concentration: > 170000 nM
Compound 4: no number, only a limit (the forecaster's own chance of this, stated with the estimate: 15%); at least 1.7-fold (0.23 log units) between middle value and limit.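

In this assay, trifluoromethyl in place of hydrogen on an aromatic carbon moves the number the same way on the core of compound 3 as on the core of compound 1, giving an at least 16-fold higher number from compound 3 to compound 4 (1.20 log units; beyond the scatter). Compound 4 gives > 170000 nM, which is a limit of the assay and not a number. The direction of the change therefore carries over between these two cores, on one pair each, but whether its size carries over is not shown: the same change on two cores in this assay, a 9.8-fold higher number (0.99 log units; beyond the scatter) from compound 1 to compound 2 and an at least 16-fold higher number (1.20 log units; beyond the scatter) from compound 3 to compound 4; the limit leaves it open whether they differ.

The compounds shown leave open whether the same direction holds when a chlorine atom, a nitrile or a methoxy group enters in place of the added trifluoromethyl, and whether it survives on a core with a longer chain or an amine in the linker. From the compounds shown here alone, the actual value of compound 4 in this assay also remains open, so any size for this step beyond its printed floor would be a guess.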